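Swapping the Ring on the Ether Side Chain

The compounds below may be only part of what the source reports. "The series", "measured", "known", "first", "only" and "open" are said of these compounds alone.

Compound 1 `c1ccc(-c2ccccc2OCc2c[nH]cn2)cc1` — 302 nM
Compound 2 `CCN(CC)C(=O)c1ccccc1OCC1=NCCN1` — < 30200 nM

In an assay for binding affinity to Alpha-1A adrenergic receptor (Homo sapiens) (on this read-out lower numbers stand for stronger inhibition and higher numbers for weaker inhibition), compound 1 gives 302 nM. For compound 2 the assay reports only a limit, < 30200 nM, so its true value is not known, as the limit of < 30200 nM in this assay, at which 1 of the 2 values shown sits, notes. Compound 3 `CCN(CC)C(=O)c1ccccc1OCc1c[nH]cn1` carries a group of 5 heavy atoms (3 carbon, 2 nitrogen; one five-membered aromatic ring with 2 hetero atoms) in place of a group of 5 heavy atoms (3 carbon, 2 nitrogen; one five-membered non-aromatic ring with 2 hetero atoms), on a saturated chain carbon bound to an oxygen on an aromatic ring. Because compound 2 stands at the limit of < 30200 nM in this assay, at which 1 of the 2 values shown sits, no step size can be read from the measurements; the expected step from compound 2 to compound 3 is a step that the limit leaves unreadable from compound 2 to compound 3. For compound 3 the estimate is 4000 nM, with a likely range from 600 nM to 25000 nM.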

Compound 3, half-maximal inhibitory concentration: < 30200 nM
Compound 3: only a limit was reported; the forecaster's own chance of this, stated with the estimate: 25%; the middle value lies beyond the limit too.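

No step from compound 2 to compound 3 can be read, because each is reported only as a limit: the limit of < 30200 nM in this assay, at which 2 of the 3 values shown sit.

The compounds shown leave open how the 1H-imidazol-4-yl group in compound 3 truly compares with the non-aromatic ring in compound 2.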